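The compounds below may be only part of what the source reports. "The series", "measured", "known", "first", "only" and "open" are said of these compounds alone.

In a functional assay on SW-620 cells (Homo sapiens) for inhibition, read by MTT assay, with a stated time of 72 h (a higher number here means a weaker inhibitor, a lower number a stronger inhibitor), the three measured compounds give:

Compound 1 `COc1cc(NC(C)CCCNC(=O)NNC(=O)Nc2ccc(Br)cc2)c2ncccc2c1`: 17000 nM
Compound 2 `COc1cc(NC(C)CCCNC(=O)Nc2ccc(C(F)(F)F)cc2)c2ncccc2c1`: 22000 nM
Compound 3 `COc1cc(NC(C)CCCNC(=O)NNC(=O)Nc2cccc(Cl)c2)c2ncccc2c1`: 25000 nM

Compound 3 has the highest of these three numbers, yet the step of a 1.1-fold higher number from compound 2 to compound 3 (0.06 log units; within the scatter) and the step of a 1.5-fold higher number from compound 1 to compound 3 (0.17 log units; within the scatter) both lie within the scatter, so the three cannot be told apart.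

Compound 4 `COc1cc(NC(C)CCCNC(=O)Nc2cccc(F)c2)c2ncccc2c1` differs from compound 3 by 3-fluorophenyl in place of ((3-chlorophenyl)carbamoyl)amino on an amide-type nitrogen.

The step of a 1.1-fold higher number from compound 2 to compound 3 (0.06 log units; within the scatter) is the same kind of exchange run the other way, and a 1.3-fold higher number from compound 1 to compound 2 (0.11 log units; within the scatter) is of the same kind too; neither moved beyond the scatter. Compound 4 is therefore expected to show a 1.1-fold lower number from compound 3 to compound 4 (0.06 log units; within the scatter), nothing beyond the scatter. Compound 4 is estimated at 22000 nM, with a range from 8000 nM to 60000 nM.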

Compound 4, half-maximal inhibitory concentration: 27000 nM
For compound 4 the middle estimate is 1.2-fold (0.09 log units) below the measured one; measured number inside the range.
By their numbers in this assay, from the lowest: compounds 1, 2, 3 and 4 (each within the scatter of the next).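

In this assay, 3-fluorophenyl in place of the larger ((3-chlorophenyl)carbamoyl)amino gives no readable difference (a 1.1-fold higher number from compound 3 to compound 4 (0.03 log units; within the scatter)). The comparisons with the other two compounds read the same way (a 1.2-fold higher number from compound 2 to compound 4 (0.09 log units; within the scatter)) (a 1.6-fold higher number from compound 1 to compound 4 (0.20 log units; within the scatter)). On this amide-type nitrogen, then, the carbamoylamino groups and the plain phenyl groups cannot be told apart, even though the 3-fluorophenyl group has no hydrogen-bond donors. No measurement here offers a reason for this flat result. On these data alone, whether an amine, a carboxylic acid or a longer chain at this place would move the number beyond the scatter remains open.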